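Replacing (propylcarbonyl)oxy with diethylamino on compound 3

The source may hold more compounds than are shown below. What is called first, only, known or untested is meant among the compounds shown, and "the series" means these compounds.

Measured in a functional assay on L1210 cells (Mus musculus) for inhibition; on this read-out lower numbers stand for stronger inhibition and higher numbers for weaker inhibition:
- Compound 1 `COC1=CC(=O)c2ncnc(NCCCN(C)C)c2C1=O`: 1730 nM
- Compound 2 `COC(=O)CNc1ncnc2c1C(=O)C(OC)=CC2=O`: 4260 nM
- Compound 3 `CCCC(=O)OCCNc1ncnc2c1C(=O)C(OC)=CC2=O`: 2660 nM

Compound 3 lies within the scatter of both other compounds, although those two stand apart: a 2.5-fold higher number from compound 1 to compound 2 (0.39 log units; beyond the scatter). The next compound to be tested is compound 4 `CCN(CC)CCNc1ncnc2c1C(=O)C(OC)=CC2=O`, which keeps the shared core and changes the side chain of compound 3: diethylamino in place of (propylcarbonyl)oxy on a saturated chain carbon, two bonds along the chain from a nitrogen on an aromatic ring. In words, diethylamino stands in place of (propylcarbonyl)oxy on a saturated chain carbon, two bonds along the chain from a nitrogen on an aromatic ring.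

The closest guide is an exchange at the same place in the opposite sense, with (propylcarbonyl)oxy in place of (dimethylamino)methyl: a 1.5-fold higher number from compound 1 to compound 3 (0.19 log units; within the scatter). The side-chain change in a 1.6-fold lower number from compound 2 to compound 3 (0.20 log units; within the scatter) also stayed small. For the measured compounds named here, no measured compound carries diethylamino, so this comparison is only indirect. A small shift towards the value of compound 1 is therefore the most that these data suggest, with no step beyond the scatter expected in this assay. The estimated change is a 1.3-fold lower number from compound 3 to compound 4 (0.12 log units; within the scatter). The expected value for compound 4 is 2000 nM, within an estimated range of 900 nM to 4400 nM.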

Compound 4, half-maximal inhibitory concentration: 898 nM
Beside the measured number, compound 4's estimate is 2.2-fold (0.35 log units) above it; the measured number lies below the stated range.
By their numbers in this assay, from the lowest: compounds 4, 1, 3 and 2 (each within the scatter of the next, the first and the last beyond it).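

In this assay, for the compounds shown here, diethylamino is the first replacement on this chain to separate clearly from (propylcarbonyl)oxy, with a 3.0-fold lower number from compound 3 to compound 4 (0.47 log units; beyond the scatter) on a change of similar size by heavy-atom count, whereas compound 3 had stood within the scatter of both earlier compounds. The contrast with the methoxycarbonyl side chain is larger, at a 4.7-fold lower number from compound 2 to compound 4 (0.68 log units; beyond the scatter), while the comparison with the (dimethylamino)methyl side chain, a 1.9-fold lower number from compound 1 to compound 4 (0.28 log units; within the scatter), stays within the scatter, so the two side chains ending in an amine group read alike, although compound 3 also remains within the scatter of compound 1. No measurement shown here explains the shift from (propylcarbonyl)oxy to diethylamino.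

The compounds shown leave open whether this result is particular to diethylamino or would extend to other amines at this place, such as a piperidine or a primary amine on the same chain. They also leave open how a carboxylic acid on this chain, or a longer chain ending in diethylamino, would read in this assay.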